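A few compounds are considered here, and "the series" means these few. Any claim that something is new, unique, unknown or untested is made for them only; others in the source may bear on it.

In a functional assay on the whole organism (strain Sprague-Dawley) for inhibition, with Rattus norvegicus as the target, with a stated time of 10 min (on this read-out lower numbers stand for an effect already at smaller amounts and higher numbers for an effect only at larger amounts of compound), three compounds have been measured:

Compound 1 `Nc1ccccc1-c1ncc(C(=O)O)c(=O)[nH]1`: 50 mg/kg
Compound 2 `CCOc1ccccc1-c1ncc(C(=O)O)c(=O)[nH]1`: 0.5 mg/kg
Compound 3 `O=C(O)c1cnc(-c2ccccc2OCC2CC2)[nH]c1=O`: 0.1 mg/kg

Compound 3, at 0.1 mg/kg, has the lowest number of the three, and its steps to both others lie beyond the scatter. Compound 4 `C[S+]([O-])c1ccccc1-c1ncc(C(=O)O)c(=O)[nH]1` has not yet been measured. It differs from compound 3 as follows: a group of 3 heavy atoms (1 carbon, 1 oxygen, 1 sulfur; no ring) in place of a group of 5 heavy atoms (4 carbon, 1 oxygen; one three-membered non-aromatic ring of carbon only), on an aromatic carbon. The change lies on an aromatic carbon of a six-membered aromatic ring of carbon only, ortho to a large group.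

All three measured steps concern this same place. Two are large: a 100-fold lower number from compound 1 to compound 2 (2.00 log units; beyond the scatter), and a 500-fold lower number from compound 1 to compound 3 (2.70 log units; beyond the scatter). The third is modest: a 5.0-fold lower number from compound 2 to compound 3 (0.70 log units; beyond the scatter). So the number has moved strongly with the group at this place, and less between ethoxy and cyclopropylmethoxy. Going by the values given here, no measured compound carries a sulfur-containing group here, so the data offer no direct precedent for compound 4. The entering group is neither of the two that gave the low numbers, which points to a move toward a higher number, though probably not the whole distance back to compound 1 at 50 mg/kg.

The expected change is a 10-fold higher number from compound 3 to compound 4 (1.00 log units; beyond the scatter). The estimated value for compound 4 is 1 mg/kg, with an expected range from 0.15 mg/kg to 10 mg/kg.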

Compound 4, dose for 50% inhibition: > 5 mg/kg
Compound 4: a limit, no number (the forecaster's own chance of this, stated with the estimate: 10%); middle value at least 5.0-fold (0.69 log units) away from the limit.
By their numbers in this assay, from the lowest: compound 3; then compound 2; then compound 1.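

In this assay compound 4 is recorded only as a limit of the assay, not as a number: the limit of > 5 mg/kg in this assay, at which 1 of the 4 values shown sits.

Even so, the limit allows two steps to be read: an at least 50-fold higher number from compound 3 to compound 4 (1.69 log units; beyond the scatter), and an at least 10-fold higher number from compound 2 to compound 4 (1.00 log units; beyond the scatter). Going by these compounds alone, the second step is the more telling, as ethoxy and the entering group both count 3 heavy atoms, 0 hydrogen-bond donors and 1 hydrogen-bond acceptor, so at this aromatic carbon these counts alone do not keep the number low, which the earlier compounds could not show. The step from compound 1 to compound 4 cannot be read, so the limit does not place these two compounds relative to each other.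

On these data alone, how far the true number of compound 4 lies beyond its limit remains open, and with it whether this group is comparable to amino at this position. A methylthio or a methylsulfonyl group here would bear on whether the higher number goes with the sulfur atom itself or with the oxygen on it, and a longer chain such as propoxy would show how far the low numbers extend among ether groups.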